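The compounds below may be only part of what the source reports. "The series", "measured", "known", "first", "only" and "open" are said of these compounds alone.

Measured so far:
compound 1 `N#C/N=C(\NCc1ccc(S(=O)(=O)c2cccc(C(F)(F)F)c2)cc1)Nc1ccncc1` — 2.4 nM
compound 2 `N#C/N=C(\NCc1ccc(S(=O)(=O)N2CC3CCC(C2)O3)cc1)Nc1ccncc1` — 2.4 nM

Both values come from an assay on isolated protein for inhibition of Nicotinamide phosphoribosyltransferase (Homo sapiens), read by mass spectrometry, with stated times of 15 min and 30 min; on this read-out lower numbers stand for stronger inhibition and higher numbers for weaker inhibition. Among the compounds with values here, on these numbers compound 1 stands level with compound 2, and the one step between them, no change at the digits printed from compound 1 to compound 2 (within the scatter), exchanges the whole group on the sulfonyl sulfur without moving the read-out beyond the scatter.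

Compound 3 `N#C/N=C(\NCc1ccc(S(=O)(=O)C2CCCCC2)cc1)Nc1ccncc1` is not yet measured. It differs from compound 1 in one place: cyclohexyl in place of 3-(trifluoromethyl)phenyl on a sulfonyl sulfur. Within the data shown here, the only step that bears on this is no change at the digits printed from compound 1 to compound 2 (within the scatter), which shows that a sizeable change at the same sulfonyl sulfur left this assay unchanged. That gives no ground to expect a large step for compound 3 either, in either direction, so the expected step of a 1.5-fold higher number from compound 1 to compound 3 (0.16 log units; within the scatter) is small.

Compound 3 is therefore estimated to give 3.5 nM in this assay, with a range from 1 nM to 12 nM.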

Compound 3, half-maximal inhibitory concentration: 5.4 nM
Compound 3: middle estimate off by 1.5-fold (0.19 log units), on the low side; low and high end bracket the measured number.
By their numbers in this assay, from the lowest: compounds 1 and 2 (each within the scatter of the next); then compound 3.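

In this assay, the group on the sulfonyl sulfur turns out not to be freely interchangeable: cyclohexyl gives a 2.3-fold higher number from compound 1 to compound 3 (0.35 log units; beyond the scatter), and the same modest rise appears as a 2.3-fold higher number from compound 2 to compound 3 (0.35 log units; beyond the scatter). Within the data shown here, the earlier pair showed only that two very different groups could read alike, whereas compound 3 shows that this position can respond to the exchange, though only slightly, since compound 3 still reads 5.4 nM. Nothing measured here says what lies behind this small rise.

On these data alone, the step from compound 1 replaces the aromatic ring and removes the trifluoromethyl at once, so what a plain phenyl on the sulfonyl sulfur would give remains open. Also open, as far as these compounds go, is how a small methyl, or a cyclohexyl carrying an amine or a carboxylic acid, would read at this position.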